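Working notes on a three-compound antiproliferative series

The source may report more compounds than this note shows. Statements on the series, on what has been measured and on what is new or still open speak of the compounds shown alone.

compound 1 `Cc1[nH]n(-c2nc3cc(Cl)ccc3[nH]2)c(=O)c1Cc1ccccc1` — 87%
compound 2 `Cc1nn(-c2nc3ccccc3[nH]2)c(O)c1Cc1ccccc1` — 90%
compound 3 `Cc1ccc2[nH]c(-n3[nH]c(C)c(Cc4ccc(Cl)cc4)c3=O)nc2c1` — 90%

In a functional assay on DU-145 cells (Homo sapiens) for antiproliferative activity, read by WST assay, with a stated time of 7 days, tested at 10 uM (a higher number here means a stronger effect of the compound at the concentration tested, a lower number a weaker effect), compound 1 gives 87%, the lowest of the three numbers. Compound 2 gives 90% and compound 3 gives 90%; both lie within the scatter of compound 1, so no order among the three can be read.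

Compound 4 `Cc1[nH]n(-c2nc3cc(-c4ccc(Cl)cc4)ccc3[nH]2)c(=O)c1Cc1ccccc1` differs from compound 1 in one place: 4-chlorophenyl in place of chloro on an aromatic carbon. What enters carries one six-membered aromatic ring of carbon only where a single heavy atom leaves. Going by the values given here, no pair of measured compounds covers a change of this kind, so the direction rests on the clustering of the measured numbers alone. The step of a number 3 percentage points lower from compound 1 to compound 4 (within the scatter) is expected to be small, downward if anything, and possibly no larger than the scatter. Compound 4 is expected to give about 84%, within a range from 65% to 95%.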

Compound 4, a percentage reported as inhibition, at one concentration (the size of the read-out at that concentration, not a potency): 100%
Beside the measured number, compound 4's estimate is 16 percentage points below it, and the stated range ends below it.
By their numbers in this assay, from the lowest: compounds 1, 2, 3 and 4 (each within the scatter of the next, the first and the last beyond it).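

In this assay the change to 4-chlorophenyl in place of chloro on an aromatic carbon gives a number 13 percentage points higher from compound 1 to compound 4 (beyond the scatter) and shows what compounds 1, 2 and 3 could not: this position accepts a much larger group carrying a six-membered aromatic ring, with no loss of the read-out. Nothing at hand bears on the reason for this gain.

From the compounds shown here alone, whether an amine, a carboxylic acid or an unsubstituted phenyl at this position would keep the read-out remains open. Going by these compounds, with one concentration only, the potency of compound 4 also remains open.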